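The compounds below may be only part of what the source reports. "The series", "measured", "known", "first", "only" and "open" are said of these compounds alone.

Measured compounds in an ADME assay on cells (Fibroblast, Homo sapiens) for antiproliferative activity, read by sulforhodamine B assay, with a stated time of 48 h; on this read-out higher numbers stand for weaker inhibition and lower numbers for stronger inhibition:
compound 1 `CCCCCCCCNC(=O)[C@@H]1CSC(c2cc(OC)c(OC)c(OC)c2)N1` gives 20800 nM
compound 2 `CCCCCCCCCCCCCCNC(=O)[C@@H]1CSC(c2cc(OC)c(OC)c(OC)c2)N1` gives 2600 nM
compound 3 `CCCCCCCCCCCCCCCCNC(=O)[C@@H]1CSC(c2cc(OC)c(OC)c(OC)c2)N1` gives 2400 nM

Compound 3 has the lowest number of the three in this assay. Its nearest neighbour is compound 2, and the step of a 1.1-fold lower number from compound 2 to compound 3 (0.03 log units; within the scatter) lies within the scatter, so the two cannot be ordered. Compound 1 lies furthest off, with an 8.7-fold lower number from compound 1 to compound 3 (0.94 log units; beyond the scatter) beyond the scatter, and likewise an 8.0-fold lower number from compound 1 to compound 2 (0.90 log units; beyond the scatter). Both of these steps concern only the length of the chain on the amide-type nitrogen; the 3,4,5-trimethoxyphenyl group is unchanged throughout.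

Compound 4 `CCCCCCCCCCCCCCCCNC(=O)[C@@H]1CSC(c2ccc(OC)c(OC)c2)N1` differs from compound 3 by hydrogen in place of methoxy on an aromatic carbon. Going by the values given here, no measured step bears on this change: all three measured compounds carry the 3,4,5-trimethoxyphenyl group, and nothing shows how the number in this assay answers to the loss of one methoxy group. The expected step of a 1.5-fold higher number from compound 3 to compound 4 (0.16 log units; within the scatter) is therefore set with no direction, small against the chain-length steps, and with a wide range to cover either outcome. Compound 4 is estimated at 3500 nM in this assay, within 1000 nM to 14000 nM.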

Compound 4, half-maximal inhibitory concentration: 2100 nM
The estimate for compound 4 lay 1.7-fold (0.22 log units) above the measured number; measured number inside the range.
By their numbers in this assay, from the lowest: compounds 4, 3 and 2 (each within the scatter of the next); then compound 1.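

Working notes: in this assay the step of a 1.1-fold lower number from compound 3 to compound 4 (0.06 log units; within the scatter) gives the first reading at this aromatic carbon, ortho to a methoxy group and meta to a large group, and it does not separate the two compounds. With the chain on the amide-type nitrogen held constant, the 3,4-dimethoxyphenyl and 3,4,5-trimethoxyphenyl groups therefore cannot be told apart here, while the chain-length step an 8.7-fold lower number from compound 1 to compound 3 (0.94 log units; beyond the scatter) lies beyond the scatter. Nothing available explains this result.

From the compounds shown here alone, the reading comes from a single pair on the longest chain, so it remains open whether hydrogen in place of methoxy reads the same way on the shorter chain of compound 1. Also open, going by these compounds, is how the number would answer to a hydroxyl group, a fluorine atom or a carboxylic acid at this aromatic carbon, and whether the 3,4-dimethoxyphenyl group would read the same way with a still longer chain on the amide-type nitrogen.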